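Sulfonyl group change from compound 3 to compound 4

A few compounds are considered here, and "the series" means these few. Any claim that something is new, unique, unknown or untested is made for them only; others in the source may bear on it.

Measured so far in a functional assay on VCaP cells (Homo sapiens) for antiproliferative activity, read by propidium iodide staining, with a stated time of 96 h; on this read-out lower numbers stand for stronger inhibition and higher numbers for weaker inhibition
compound 1 `CC(O)(CS(=O)(=O)c1ccc(S(F)(F)(F)(F)F)cc1)C(=O)Nc1cccc(S(F)(F)(F)(F)F)c1` gives 17200 nM
compound 2 `CC(O)(CS(=O)(=O)c1cccc(C(F)(F)F)c1)C(=O)Nc1cccc(S(F)(F)(F)(F)F)c1` gives 35500 nM
compound 3 `CC(O)(CS(=O)(=O)c1ccccc1C(F)(F)F)C(=O)Nc1cccc(S(F)(F)(F)(F)F)c1` gives 40800 nM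

Compound 3 (40800 nM) lies within the scatter of compound 2 and sits beyond the scatter on the higher side of compound 1. The next change leads to compound 4 `CC(O)(CS(=O)(=O)c1ccc(OC(F)(F)F)cc1)C(=O)Nc1cccc(S(F)(F)(F)(F)F)c1` and is counted as 4-(trifluoromethoxy)phenyl in place of 2-(trifluoromethyl)phenyl on a sulfonyl sulfur with 4-(trifluoromethoxy)phenyl in place of 2-(trifluoromethyl)phenyl on a sulfonyl sulfur. Among the compounds with values here, no measured step introduces this group. Only a 1.1-fold higher number from compound 2 to compound 3 (0.06 log units; within the scatter) concerns the trifluoromethyl-bearing groups on the sulfonyl sulfur, and it stays within the scatter, so this small series gives no sign of a large swing from such a change. Compound 1 (17200 nM) is the closest measured compound to compound 4 by structure, which pulls the expectation toward lower numbers. The expected step in this assay is a 1.7-fold lower number from compound 3 to compound 4 (0.23 log units; within the scatter) and no larger change is anticipated, though the evidence for its direction is thin. The estimate for compound 4 is 24000 nM with an expected range of 11000 nM to 48000 nM in this read-out.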

Compound 4, half-maximal inhibitory concentration: 15100 nM
The estimate for compound 4 lay 1.6-fold (0.20 log units) above the measured number; low and high end bracket the measured number.
By their numbers in this assay, from the lowest: compounds 4 and 1 (each within the scatter of the next); then compounds 2 and 3 (each within the scatter of the next).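

In this assay, the earlier change among trifluoromethyl-bearing groups on the sulfonyl sulfur, a 1.1-fold higher number from compound 2 to compound 3 (0.06 log units; within the scatter), gave no measurable shift, whereas 4-(trifluoromethoxy)phenyl on that sulfur gives a 2.7-fold lower number from compound 3 to compound 4 (0.43 log units; beyond the scatter) and a 2.4-fold lower number from compound 2 to compound 4 (0.37 log units; beyond the scatter), so the aryl group at this position can move the number modestly beyond the scatter. The step to the group of 5 heavy atoms from the group of 6 heavy atoms on an aromatic carbon, a 1.1-fold lower number from compound 1 to compound 4 (0.06 log units; within the scatter), stays within the scatter, so these two groups cannot be told apart on this read-out. No measurement here bears on the reason for these shifts.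

The 4-(trifluoromethoxy)phenyl group differs from both trifluoromethyl-bearing groups in its substituent as well as in the printed ring number, so these steps cannot assign the shift to either feature, and a 4-(trifluoromethyl)phenyl group on the sulfonyl sulfur would separate the two. Also open, as far as these compounds go, is how this read-out would respond to a nitrile or a carboxylic acid on that ring, or to an amine on the ring that carries the amide nitrogen.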